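Removing the chloro group from compound 2

This account rests on a few compounds, and the source may have more. Where it says the series, first, only, none or still open, it means among the compounds named here.

Measured so far in a functional assay on HeLa cells (Homo sapiens) for antiproliferative activity, read by MTT assay, with a stated time of 72 h; a higher number here means a weaker inhibitor, a lower number a stronger inhibitor:
- compound 1 (`COc1ccc(-c2ncnn2-c2cc(OC)c(OC)c(OC)c2)cc1`) gives 280 nM
- compound 2 (`CCOc1ccc(-c2ncnn2-c2cc(OC)c(OC)c(OC)c2)cc1Cl`) gives 6 nM

In this assay compound 2 holds the lower of the two numbers, and its gap to compound 1 lies beyond the usual scatter. Compound 3 (`CCOc1ccc(-c2ncnn2-c2cc(OC)c(OC)c(OC)c2)cc1`) follows from compound 2 with hydrogen in place of chloro on an aromatic carbon. For the measured compounds named here, the two measured compounds differ in more than one place, so no measured step isolates this change. Compound 3 keeps the ethoxy group of compound 2, measured at 6 nM, but lacks chloro, as does compound 1 at 280 nM, so a number between these two is expected. The expected change, a 10-fold higher number from compound 2 to compound 3 (1.00 log units; beyond the scatter), is a rise beyond the scatter, towards a weaker inhibitor. For compound 3 the estimated value is 60 nM, with an expected range from 15 nM to 250 nM.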

Compound 3, half-maximal inhibitory concentration: 15 nM
For compound 3 the middle estimate is 4.0-fold (0.60 log units) above the measured one, within the range that was stated.
By their numbers in this assay, from the lowest: compound 2; then compound 3; then compound 1.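

In this assay the chloro group, on an aromatic carbon ortho to an ethoxy group, now has a step of its own, with a 2.5-fold higher number from compound 2 to compound 3 (0.40 log units; beyond the scatter) as a modest change that still lies beyond the scatter. Methyl in place of hydrogen on the saturated chain carbon is isolated as well, with a 19-fold lower number from compound 1 to compound 3 (1.27 log units; beyond the scatter) as a large change, so in this series the extension from methoxy to ethoxy accounts for more of the distance between the two earlier compounds than the chloro group does. No measurement shown here gives a reason for either step.

Going by these compounds, the size of the chloro step on a methoxy compound stays open, since both steps are read on the ethoxy compound or against it. Also open, on these data alone, is how a longer chain such as propoxy would compare with ethoxy, and how a fluoro or bromo group would compare with chloro at the same carbon.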